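This account rests on a few compounds, and the source may have more. Where it says the series, first, only, none or still open, it means among the compounds named here.

Measured in a functional assay on the whole organism with Mus musculus as the target; on this read-out lower numbers stand for an effect already at smaller amounts and higher numbers for an effect only at larger amounts of compound:
- Compound 1 `CNC(=O)[C@@H](C)NCc1ccc(OCc2ccccc2)cc1`: 40.5 mg/kg
- Compound 2 `C[C@@H](NCc1ccc(COc2ccccc2)cc1)C(N)=O`: 40.3 mg/kg
- Compound 3 `CNC(=O)[C@@H](CO)NCc1ccc(OCc2ccc(Cl)cc2)cc1`: 216 mg/kg

Compound 3 has the highest number of the three, so it needs the largest dose for half-maximal effect. Its number lies clearly beyond the usual scatter from both of the others, while compound 1 and compound 2 show essentially the same value.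

The next compound, compound 4 `CNC(=O)[C@@H](CO)NCc1ccc(OCc2ccccc2F)cc1`, keeps all of compound 3 except one group: 2-fluorophenyl in place of 4-chlorophenyl on a saturated chain carbon bound to an oxygen on an aromatic ring. In words, 2-fluorophenyl takes the place of 4-chlorophenyl on a saturated chain carbon bound to an oxygen on an aromatic ring.

Going by the values given here, no measured pair shows this swap alone, so any prediction is uncertain. Only compound 3 carries the 4-chlorophenyl group, and a moderate move towards lower numbers seems likely once it leaves. The rest of compound 3 stays, however, so a full drop to the level of compound 1 at 40.5 mg/kg is not the central expectation.

The expected change is a 2.2-fold lower number from compound 3 to compound 4 (0.33 log units; beyond the scatter).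

For compound 4, the estimated value is 100 mg/kg, with an expected range from 40 mg/kg to 250 mg/kg.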

Compound 4, dose for half-maximal effect: 12.4 mg/kg
The estimate for compound 4 lay 8.1-fold (0.91 log units) above the measured number, outside the stated range (below it).
By their numbers in this assay, from the lowest: compound 4; then compounds 2 and 1 (each within the scatter of the next); then compound 3.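

In this assay, putting 2-fluorophenyl in place of 4-chlorophenyl on a saturated chain carbon bound to an oxygen on an aromatic ring gives a 17-fold lower number from compound 3 to compound 4 (1.24 log units; beyond the scatter) and counts as a large step, beyond the scatter. This position is therefore far from indifferent: the rest of the molecule stays the same, and the two groups have the same count of heavy atoms, yet the dose needed shifts strongly. No measurement shown bears on the cause of this step.

The swap changes both the halogen and its place on the ring, so the two changes cannot be separated here. A 2-chlorophenyl or 4-fluorophenyl group at this place, or an unsubstituted phenyl on the same scaffold, would show whether the halogen, its place or both account for the step.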